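Selenium chain in place of methoxy on the shared core

A few compounds are considered here, and "the series" means these few. Any claim that something is new, unique, unknown or untested is made for them only; others in the source may bear on it.

Compound 1 `OCC#CCSc1cnc2ccccc2c1SCC#CCO` gives 32 ug/mL in a functional assay on SW707 cells (Homo sapiens) for cytotoxicity, read by sulforhodamine B assay, with a stated time of 72 h; a higher number here means a weaker inhibitor, a lower number a stronger inhibitor. For the measured compounds named here, compound 2 `COc1c(SCC#CCO)cnc2ccccc12` gives 67.4 ug/mL in this assay and so holds the highest of the two numbers; the only step toward it, a 2.1-fold higher number from compound 1 to compound 2 (0.32 log units; beyond the scatter), is modest. Compound 3 `C#CC[Se]c1c(SCC#CCO)cnc2ccccc12` differs from compound 2 in one place: a group of 4 heavy atoms (3 carbon, 1 selenium; no ring) in place of a group of 2 heavy atoms (1 carbon, 1 oxygen; no ring), on an aromatic carbon. Going by the values given here, the single step that bears on this change, a 2.1-fold higher number from compound 1 to compound 2 (0.32 log units; beyond the scatter), runs the opposite way, trading the methoxy for a group of 4 heavy atoms on the aromatic carbon. A modest lowering in this assay is therefore expected, a 1.7-fold lower number from compound 2 to compound 3 (0.23 log units; within the scatter). Compound 3 is estimated at 40 ug/mL, with a range from 20 ug/mL to 80 ug/mL.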

Compound 3, concentration for 50% inhibition: 3.8 ug/mL
Estimate against measurement, compound 3: 11-fold (1.02 log units) above; the measured number lies below the stated range.
By their numbers in this assay, from the lowest: compound 3; then compound 1; then compound 2.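

In this assay the selenium chain on this aromatic carbon, opposite the ring nitrogen, brings an 18-fold lower number from compound 2 to compound 3 (1.25 log units; beyond the scatter) when it replaces methoxy and an 8.4-fold lower number from compound 1 to compound 3 (0.93 log units; beyond the scatter) when it replaces the group of 6 heavy atoms. For the compounds shown here, this carbon therefore responds to its substituent far more strongly than the one earlier step showed, and compound 3 holds the lowest number of the three, beyond the scatter against both others.

On these data alone, whether the selenium atom or the triple bond matters more stays open; the same chain on sulfur, or a propyl chain on selenium, would separate the two. No measurement at hand accounts for the size of this drop.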